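Watching One Side-Chain Swap in a Cell Toxicity Assay

A few compounds are considered here, and "the series" means these few. Any claim that something is new, unique, unknown or untested is made for them only; others in the source may bear on it.

Of the compounds shown here, three that share one core have so far been measured in a toxicity assay on Vero cells (Chlorocebus sabaeus) for inhibition; on this read-out lower numbers stand for an effect already at smaller amounts and higher numbers for an effect only at larger amounts of compound. Compound 1 `COc1cccc(NC(=O)c2nnn(C(CO)c3ccc(C(C)C)cc3)c2N)c1` gives 12600 nM. Compound 2 `COc1cccc(NC(=O)c2nnn(CC3CCN(C(C)=O)CC3)c2N)c1` reaches only the limit of the assay, > 50100 nM, so no number is known for it. Compound 3 `COc1cccc(NC(=O)c2nnn(CC3CCN(C(=O)OC(C)(C)C)CC3)c2N)c1` likewise reaches only a limit, > 50100 nM. Because of the limit of > 50100 nM in this assay, at which 2 of the 3 values shown sit, the step that the two limits leave unreadable from compound 2 to compound 3 cannot be read. Compound 2 therefore stands at the edge of what the assay can report, and only compound 1 provides a real number among the three.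

Compound 4 `COc1cccc(NC(=O)c2nnn(Cc3ccc([S+](C)[O-])cc3)c2N)c1` has not yet been measured. It differs from compound 2 in one place: a group of 9 heavy atoms (7 carbon, 1 oxygen, 1 sulfur; one six-membered aromatic ring of carbon only) in place of a group of 9 heavy atoms (7 carbon, 1 nitrogen, 1 oxygen; one six-membered non-aromatic ring with 1 hetero atom), on a saturated chain carbon bound to an aromatic nitrogen. Among the compounds with values here, no measured step carries the same change, and the one step that starts from compound 2 is unreadable, so neither size nor direction can be taken from it. Within the data shown here, the only hint is compound 1, which also carries a six-membered aromatic ring on the saturated chain carbon bound to the aromatic nitrogen and still gives a number within the assay range. Compound 4 is therefore expected to give 40000 nM, somewhere between 15000 nM and 110000 nM. The step this estimate implies, an at least 1.2-fold lower number from compound 2 to compound 4 (0.09 log units; that floor lies within the scatter), is expected to stay within the scatter or remain unreadable.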

Compound 4, half-maximal effective concentration: > 50100 nM
Compound 4 gave a limit, no number (the forecaster's own chance of this, stated with the estimate: 55%); at least 1.2-fold (0.09 log units) between middle value and limit.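

Compound 4 gives a limit and not a number, as compound 2 does, so the step from compound 2 to compound 4 cannot be read, and the reason is this: the limit of > 50100 nM in this assay, at which 3 of the 4 values shown sit.

The compounds shown leave open whether swapping the group on the saturated chain carbon changes the read-out at all.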